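Fluoro in place of carboxy on the aryl ring

The source may hold more compounds than are shown below. What is called first, only, known or untested is meant among the compounds shown, and "the series" means these compounds.

Measured so far in an assay on CHO cells for displacement of a labelled ligand from adenosine receptor A3 (Homo sapiens), read by scintillation counting, with a stated time of 3 h; a lower number here means a stronger inhibitor, a higher number a weaker inhibitor:
compound 1, `Cn1c(-c2ccccc2)nc2c(NC3CCCC3)ncnc21`, 846 nM
compound 2, `Cn1c(-c2ccc(C(=O)O)cc2)nc2c(NC3CCCC3)ncnc21`, 25700 nM
compound 3, `CCCn1c(-c2ccccc2)nc2c(NC3CCOC3)ncnc21`, 2810 nM

Compound 2 gives the highest number of the three; compound 3 is nearest, compound 1 furthest, and both gaps lie beyond the scatter. Compound 4, `Cn1c(-c2ccc(F)cc2)nc2c(NC3CCCC3)ncnc21`, differs from compound 2 in one place: fluoro in place of carboxy on an aromatic carbon. Within the data shown here, the single step that bears on this place is the one that brought the carboxy in, a 30-fold higher number from compound 1 to compound 2 (1.48 log units; beyond the scatter), a large rise. Taking that rise out again should recover most of the ground, so a large fall from compound 2 to compound 4 is expected in this assay, close to the number of compound 1. Compound 4 is estimated at 700 nM, between 250 nM and 2500 nM, which means an expected step of a 37-fold lower number from compound 2 to compound 4 (1.56 log units; beyond the scatter).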

Compound 4, inhibition constant: 1140 nM
Compound 4: the middle estimate sits 1.6-fold (0.21 log units) below what was measured, and the stated range covers the measured number.
By their numbers in this assay, from the lowest: compounds 1 and 4 (each within the scatter of the next); then compound 3; then compound 2.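

In this assay, fluoro at this place does not carry the loss seen with carboxy (a 23-fold lower number from compound 2 to compound 4 (1.35 log units; beyond the scatter)). Fluoro in place of hydrogen on the same aromatic carbon gives (a 1.3-fold higher number from compound 1 to compound 4 (0.13 log units; within the scatter)), so fluoro and hydrogen cannot be told apart here, and the high number of compound 2 belongs to the carboxy, not to substitution at this carbon as such. Nothing on hand accounts for the carboxy result.

Going by these compounds, whether an amide, an amine or a hydroxyl on this carbon would read with compound 2 or with compound 1 and compound 4 stays open.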